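A few compounds are considered here, and "the series" means these few. Any claim that something is new, unique, unknown or untested is made for them only; others in the source may bear on it.

Compound 1, `Cc1cccc(-c2cccc(NC3=NCCN3)c2C)c1`: in an assay for binding affinity to Adrenergic receptor alpha-1 (Rattus norvegicus) (on this read-out lower numbers stand for stronger inhibition and higher numbers for weaker inhibition), compound 1 gives 166 nM.
Compound 2, `Cc1c(NC2=NCCN2)cccc1-c1cccc(C(F)(F)F)c1`: in this assay compound 2 gives 257 nM.

Only these two numbers stand so far, and they lie close together. Within the data shown here, the single step between them, a 1.5-fold higher number from compound 1 to compound 2 (0.19 log units; within the scatter), stays within the scatter of repeated measurement, so compound 2 cannot be set apart from compound 1 on this read-out; the two may well be the same.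

Compound 3, `Cc1c(NC2=NCCN2)cccc1-c1cccc(Cl)c1`, has not yet been measured. It differs from compound 2 in one place: chloro in place of trifluoromethyl on an aromatic carbon. Among the measured compounds shown here, the only measured step that touches this position is the one from compound 1 to compound 2, where a trifluoromethyl group took the place of a methyl group on the same aromatic carbon and the number moved by a 1.5-fold higher number from compound 1 to compound 2 (0.19 log units; within the scatter), within the scatter. For the measured compounds named here, no measured pair shows a chloro group at that position, so the bearing of this change rests on that single small step alone.

The account therefore expects no step beyond the scatter in this assay: the estimated step from compound 2 is a 1.3-fold lower number from compound 2 to compound 3 (0.11 log units; within the scatter). For compound 3 the estimate in this assay is 200 nM, with a range from 80 nM to 500 nM.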

Compound 3, inhibition constant: 132 nM
Compound 3: the middle estimate sits 1.5-fold (0.18 log units) above what was measured; the measured number falls inside the stated range.
By their numbers in this assay, from the lowest: compounds 3, 1 and 2 (each within the scatter of the next).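

At this position, on an aromatic carbon meta to a large group, chloro now stands with methyl and trifluoromethyl, and in this assay the replacement of trifluoromethyl by chloro gives a 1.9-fold lower number from compound 2 to compound 3 (0.29 log units; within the scatter), while the replacement of methyl by chloro gives a 1.3-fold lower number from compound 1 to compound 3 (0.10 log units; within the scatter). With these steps, all three pairs among the groups at this position have been compared, and each lies within the scatter, so the read-out does not separate the three compounds; even the exchange of trifluoromethyl, with 4 heavy atoms, for chloro, with 1 heavy atom, stays within it. Nothing available here bears on why these three groups read alike.

The compounds shown hold only these three groups at this position, none with a hydrogen-bond donor, a hydrogen-bond acceptor or a net charge, so whether an amine, a carboxylic acid or a longer chain there would give a step beyond the scatter remains open. Going by these compounds, it also remains open whether chloro would read the same way on another carbon of that ring, or with any other part of the shared core changed.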